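A few compounds are considered here, and "the series" means these few. Any claim that something is new, unique, unknown or untested is made for them only; others in the source may bear on it.

Compound 1, `CCc1ccc(-c2nnc(COc3cnn(C(C)(C)C)c(=O)c3Cl)o2)cc1`, gives 3.52 in a physicochemical assay for lipophilicity; a higher number here means a more lipophilic compound, a lower number a more polar compound.
Compound 2, `CC(C)(C)n1ncc(OCc2nnc(-c3cc(F)c(F)cc3F)o2)c(Cl)c1=O`, gives 2.96.
Compound 3, `CC(C)(C)n1ncc(OCc2nnc(-c3ccc(Cl)cc3)o2)c(Cl)c1=O`, gives 3.09.

Among these three, compound 1 stands highest: compound 3 is nearest (a number 0.43 log units lower from compound 1 to compound 3 (beyond the scatter)) and compound 2 is furthest (a number 0.56 log units lower from compound 1 to compound 2 (beyond the scatter)). Compound 4, `Cc1ccc(-c2nnc(COc3cnn(C(C)(C)C)c(=O)c3Cl)o2)cc1`, differs from compound 1 in a single place: hydrogen in place of methyl on a saturated chain carbon bound to an aromatic carbon. Among the compounds with values here, none of the measured steps removes a methyl from a saturated chain, so the closest guide is the step from the ethyl compound to the chloro compound (a number 0.43 log units lower from compound 1 to compound 3 (beyond the scatter)), which also takes the ethyl away but puts chloro in its place. Losing one chain carbon is expected to give a modest drop beyond the scatter, a number 0.52 log units lower from compound 1 to compound 4 (beyond the scatter). Compound 4 is therefore estimated at 3, between 2.7 and 3.3.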

Compound 4, partition coefficient: 3.01
The estimate for compound 4 lay 0.01 log units below the measured number, within the range that was stated.
By their numbers in this assay, from the lowest: compounds 2, 4 and 3 (each within the scatter of the next); then compound 1.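

In this assay, the loss of a single chain carbon, ethyl to methyl, is enough for a step beyond the scatter: a number 0.51 log units lower from compound 1 to compound 4 (beyond the scatter). Methyl and chloro on the aromatic carbon do not separate, with a number 0.08 log units lower from compound 3 to compound 4 (within the scatter), and neither do 4-methylphenyl and 2,4,5-trifluorophenyl, with a number 0.05 log units higher from compound 2 to compound 4 (within the scatter). No measurement shown here explains these steps. On these data alone, what a longer chain such as propyl, or an amine, would give in place of the ethyl stays open, and so does whether the ethyl to methyl step would hold on any other core.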